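The source may report more compounds than this note shows. Statements on the series, on what has been measured and on what is new or still open speak of the compounds shown alone.

Measured so far in a functional assay on cells (Cancer cell lines, Homo sapiens) for cytotoxicity, read by sulforhodamine B assay, with a stated time of 48 h; on this read-out higher numbers stand for weaker inhibition of growth and lower numbers for stronger inhibition of growth:
compound 1, `O=C1N=C(N2N=C(c3ccccc3)CC2c2ccccc2O)S/C1=C1/C(=O)Nc2ccc(Br)cc21`, gives 800 nM
compound 2, `CN(C)c1ccc(C2CC(c3ccccc3)=NN2C2=NC(=O)/C(=C3\C(=O)Nc4ccccc43)S2)cc1`, gives 20300 nM
compound 3, `CN(C)c1ccc(C2CC(c3ccccc3)=NN2C2=NC(=O)/C(=C3\C(=O)Nc4ccc(Br)cc43)S2)cc1`, gives 510 nM

Compound 3 has the lowest of the three numbers. Its nearest neighbour is compound 1, and the step of a 1.6-fold lower number from compound 1 to compound 3 (0.20 log units; within the scatter) lies within the scatter, so these two cannot be told apart. The furthest is compound 2, and the step of a 40-fold lower number from compound 2 to compound 3 (1.60 log units; beyond the scatter) is large.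

Compound 4, `CN(C)c1ccc(C2CC(c3ccccc3)=NN2C2=NC(=O)/C(=C3\C(=O)Nc4ccc(Cl)cc43)S2)cc1`, has not yet been measured in this assay. It differs from compound 3 in one place: chloro in place of bromo on an aromatic carbon. For the measured compounds named here, only one measured step touches this position, namely a 40-fold lower number from compound 2 to compound 3 (1.60 log units; beyond the scatter), in which bromo replaced hydrogen. The present change keeps a halogen at that carbon and only swaps bromo for chloro, a smaller alteration than putting a halogen where there was none. A number between those of compound 3 and compound 2 is therefore expected, closer to compound 3, with a modest rise that may or may not exceed the scatter. Compound 4 is expected to give about 900 nM, within a range from 300 nM to 3000 nM. This corresponds to an expected step of a 1.8-fold higher number from compound 3 to compound 4 (0.25 log units; within the scatter).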

Compound 4, concentration for total growth inhibition: 530 nM
Estimate against measurement, compound 4: 1.7-fold (0.23 log units) above, and the stated range covers the measured number.
By their numbers in this assay, from the lowest: compounds 3, 4 and 1 (each within the scatter of the next); then compound 2.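

In this assay the swap of halogen gives a 1.0-fold higher number from compound 3 to compound 4 (0.02 log units; within the scatter) and so chloro and bromo on this aromatic carbon cannot be told apart. Measured against hydrogen on the same carbon, chloro gives a 38-fold lower number from compound 2 to compound 4 (1.58 log units; beyond the scatter) and this large step stands close to a 40-fold lower number from compound 2 to compound 3 (1.60 log units; beyond the scatter) for bromo, so the stronger inhibition of growth seen earlier with bromo alone is now seen with a second halogen on the same compound frame. Nothing on hand explains why either halogen differs so much from hydrogen here.

The compounds shown carry only hydrogen, chloro and bromo at this carbon, so it stays open whether fluoro, methyl, methoxy or a nitrile there would match the two halogens or fall back towards hydrogen. Going by these compounds, it is also open whether chloro and bromo stay level when the group on the saturated ring carbon changes, for example to the 2-hydroxyphenyl of compound 1, which appears here only in its bromo form.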